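Compound 4: a sulfur substituent swap on compound 2

This account rests on a few compounds, and the source may have more. Where it says the series, first, only, none or still open, it means among the compounds named here.

Values in a functional assay on SGC-7901 cells (Homo sapiens) for cytotoxicity, read by MTT assay, with a stated time of 48 h; on this read-out higher numbers stand for weaker inhibition and lower numbers for stronger inhibition:
- compound 1 `O=C(CSc1ccccc1)N1N=C(c2cc3ccccc3oc2=O)C[C@@H]1c1ccccc1`: 20300 nM
- compound 2 `CC1=NN(C(=O)CSc2ccccn2)[C@@H](c2cc(Br)cc(Br)c2O)C1`: 10300 nM
- compound 3 `CCCCSCC(=O)N1N=C(c2cc3ccccc3oc2=O)C[C@@H]1c1ccccc1`: 7300 nM

Compound 2, at 10300 nM, lies within the scatter of both other compounds, although those two differ from each other beyond it.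

The next compound is compound 4 `CC1=NN(C(=O)CSc2ccc(Br)cc2)[C@@H](c2cc(Br)cc(Br)c2O)C1`. The change is 4-bromophenyl in place of pyridin-2-yl on a sulfur.

Among the compounds with values here, only one measured step changes a group on this sulfur: a 2.8-fold lower number from compound 1 to compound 3 (0.44 log units; beyond the scatter), a modest step with butyl in place of phenyl. It belongs to a different core and involves neither group in the present change, so it bears only loosely. It suggests that a change at this sulfur can move the number modestly. The data do not fix the direction. A step to a lower number in this assay, no larger than that one, is tentatively expected.

The expected change is a 1.7-fold lower number from compound 2 to compound 4 (0.23 log units; within the scatter). For compound 4 the estimated value is 6000 nM, with an expected range of 2200 nM to 16000 nM.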

Compound 4, half-maximal inhibitory concentration: 8210 nM
Compound 4: the middle estimate sits 1.4-fold (0.14 log units) below what was measured, and the stated range covers the measured number.
By their numbers in this assay, from the lowest: compounds 3, 4, 2 and 1 (each within the scatter of the next, the first and the last beyond it).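

In this assay, the change on this sulfur gives a 1.3-fold lower number from compound 2 to compound 4 (0.10 log units; within the scatter), so on the core of compound 2, 4-bromophenyl and pyridin-2-yl cannot be told apart. Within the data shown here, the only earlier step at this sulfur, a 2.8-fold lower number from compound 1 to compound 3 (0.44 log units; beyond the scatter), lay beyond the scatter but replaced phenyl with butyl on a different core, whereas this step shows that an exchange of one aromatic ring for another, with the ring nitrogen leaving and a bromine entering, need not move the number beyond the scatter.

The ring nitrogen and the bromine changed together, so their separate contributions remain unresolved. Also open, going by these compounds, is how butyl, or a longer chain ending in an amine or a carboxylic acid, would behave on this sulfur on the core of compound 2.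

No supporting data bear on this result.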